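The source may hold more compounds than are shown below. What is called first, only, known or untested is meant among the compounds shown, and "the series" means these compounds.

In a functional assay on A2780 cells (Homo sapiens) for antiproliferative activity, read by resazurin assay, with a stated time of 72 h (on this read-out higher numbers stand for weaker inhibition and lower numbers for stronger inhibition), compound 1 (`CCCN(C)C(=O)c1cc2c(Cc3ccccc3)n[nH]c2cc1O`) gives > 10000 nM as a limit only. In this assay compound 2 (`CN(Cc1ccccc1)C(=O)c1cc2c(Cc3ccccc3)n[nH]c2cc1O`) gives 980 nM and compound 3 (`CN(C(=O)c1cc2c(Cc3ccccc3)n[nH]c2cc1O)c1ccco1`) gives 2500 nM as the higher of the two actual numbers. Compound 4 (`CN(Cc1ccccc1F)C(=O)c1cc2c(Cc3ccccc3)n[nH]c2cc1O`) carries 2-fluorobenzyl in place of furan-2-yl on an amide-type nitrogen. The nearest measured step runs the opposite way (a 2.6-fold higher number from compound 2 to compound 3 (0.41 log units; beyond the scatter)) with furan-2-yl replacing benzyl, so a modest fall in the number is expected. The steps (an at least 10-fold lower number from compound 1 to compound 2 (1.00 log units; beyond the scatter) and an at least 4.0-fold lower number from compound 1 to compound 3 (0.60 log units; beyond the scatter)) give only minimum sizes. For the measured compounds named here, no measured step covers the fluorine, and no effect is credited to it. The expected step is a 2.5-fold lower number from compound 3 to compound 4 (0.40 log units; beyond the scatter) in this assay as estimated here. For compound 4 the estimate is 1000 nM with an expected range from 350 nM to 2800 nM in this series.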

Compound 4, half-maximal inhibitory concentration: 1500 nM
For compound 4 the middle estimate is 1.5-fold (0.18 log units) below the measured one; low and high end bracket the measured number.
By their numbers in this assay, from the lowest: compounds 2, 4 and 3 (each within the scatter of the next, the first and the last beyond it). At a limit, above all of these: compound 1.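

In this assay, fluoro in place of hydrogen on the benzyl group gives no change beyond the scatter: a 1.5-fold higher number from compound 2 to compound 4 (0.18 log units; within the scatter). The same holds for the exchange of furan-2-yl for 2-fluorobenzyl on the amide-type nitrogen: a 1.7-fold lower number from compound 3 to compound 4 (0.22 log units; within the scatter). Compound 1 is a limit only, and an at least 6.6-fold lower number from compound 1 to compound 4 (0.82 log units; beyond the scatter) gives a minimum size for the step that brings in the 2-fluorobenzyl group.

The compounds shown leave open how a benzyl group carrying an amine or a carboxylic acid would read here. From the compounds shown here alone, a longer chain ending in phenyl also remains open.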